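The compounds below may be only part of what the source reports. "The series", "measured", "known", "first", "only" and "open" are said of these compounds alone.

Measured in a functional assay on RPMI 8402 cells (Homo sapiens) for cytotoxicity; on this read-out lower numbers stand for stronger inhibition and higher numbers for weaker inhibition:
Compound 1 `N#Cc1ccc2[nH]c(-c3ccc4[nH]c(-c5ccc6[nH]cnc6c5)nc4c3)nc2c1`: > 25000 nM, a limit of the assay and not a number.
Compound 2 `c1cncc(-c2ccc3[nH]c(-c4ccc5[nH]c(-c6ccc7[nH]cnc7c6)nc5c4)nc3c2)c1`: 2500 nM.

Going by the values given here, compound 2, at 2500 nM, holds the only true number in this assay. Compound 3 `c1ccc(-c2ccc3[nH]c(-c4ccc5[nH]c(-c6ccc7[nH]cnc7c6)nc5c4)nc3c2)nc1` has the same atoms, joined differently: pyridin-2-yl in place of pyridin-3-yl on an aromatic carbon. Among the compounds with values here, the one measured step, an at least 10-fold lower number from compound 1 to compound 2 (1.00 log units; beyond the scatter), exchanged cyano for pyridin-3-yl. Within the data shown here, it bears only indirectly, and no measured step exchanges one pyridinyl group for another. A change within the scatter is therefore expected, with no firm direction, as the estimated 1.4-fold lower number from compound 2 to compound 3 (0.14 log units; within the scatter). For compound 3 the expected value is 1800 nM, with an estimated range from 450 nM to 7000 nM.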

Compound 3, half-maximal inhibitory concentration: 5800 nM
Compound 3: middle estimate off by 3.2-fold (0.51 log units), on the low side; the range from low to high includes it.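

In this assay the way the pyridine ring is joined now matters: a 2.3-fold higher number from compound 2 to compound 3 (0.37 log units; beyond the scatter), so pyridin-3-yl and pyridin-2-yl, though made of the same atoms, are not interchangeable on this aromatic carbon. Either pyridinyl group still beats cyano, with pyridin-2-yl giving an at least 4.3-fold lower number from compound 1 to compound 3 (0.63 log units; beyond the scatter). Compound 1 is a limit of the assay and not a number: the limit of > 25000 nM in this assay, at which 1 of the 3 values shown sits. Going by these compounds, whether pyridin-4-yl or a plain phenyl group on this carbon would give a lower number than compound 2 remains open, as does the effect of an amine or a carboxylic acid here.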